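A Nitrile Gives Way on an Inactive Scaffold

This account rests on a few compounds, and the source may have more. Where it says the series, first, only, none or still open, it means among the compounds named here.

Compound 1 `N#Cc1cn(Cc2ccccc2)c2ncnc(N)c12` opens the series in a functional assay on KB cells (Homo sapiens) for cytotoxicity; on this read-out lower numbers stand for stronger inhibition and higher numbers for weaker inhibition. Compound 1 gives > 100000 nM, which is a limit of the assay and not a number. Compound 2 `Cc1ccccc1Cn1cc(C#N)c2c(N)ncnc21` adds a methyl in place of a hydrogen on an aromatic carbon. Compound 2 gives > 100000 nM, also a limit. The evidence so far is therefore (the limit of > 100000 nM in this assay, at which 2 of the 2 values shown sit).

Compound 3 `Cc1ccccc1Cn1cc(C(=N)S)c2c(N)ncnc21` keeps the frame of compound 2 but changes one group: a group of 3 heavy atoms (1 carbon, 1 nitrogen, 1 sulfur; no ring) in place of a group of 2 heavy atoms (1 carbon, 1 nitrogen; no ring), on an aromatic carbon. The change lies on an aromatic carbon of a five-membered aromatic ring, two ring bonds from the ring nitrogen.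

Going by the values given here, the only measured step is the methyl change, a step that the two limits leave unreadable from compound 1 to compound 2. It involves a different change and has no readable size, so it offers no size to carry over. Any readable result for compound 3 would have to lie on the stronger side of the limit held by compound 2, so the expectation leans modestly that way. The expected step is an at least 2.0-fold lower number from compound 2 to compound 3 (0.30 log units; that floor lies within the scatter). For compound 3 the estimated value is 50000 nM. The expected range runs from 8000 nM to 100000 nM.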

Compound 3, half-maximal inhibitory concentration: > 17000 nM
Compound 3: no number, only a limit; the forecaster's own chance of this, stated with the estimate: 55%; the middle value is on the limit's open side.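

In this assay compound 3 gives > 17000 nM, which is a limit of the assay and not a number. Compound 2 also holds only a limit, and the step from compound 2 to compound 3 cannot be read. The compounds shown leave open how strongly, if at all, any of them inhibits in this assay.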